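A few compounds are considered here, and "the series" means these few. Any claim that something is new, unique, unknown or untested is made for them only; others in the source may bear on it.

Measured so far:
compound 1, `O=C(O)c1ccc([C@H]2C[C@](O)(c3ccc(OCc4c(-c5c(Cl)cccc5Cl)noc4C4CC4)cc3Cl)C2)cc1` — 41%
compound 2, `O=C(O)c1cccc(C2CC2c2ccc(OCc3c(-c4c(Cl)cccc4Cl)noc3C3CC3)cc2Cl)c1` — 53%

Within the data shown here, in an ADME assay on the whole organism (strain C57BL/6J) for pharmacokinetics, with Mus musculus as the target, at a dose of 5 mg/kg by the oral route (a lower number here means that a smaller share of the oral dose reaches the circulation, a higher number that a larger share of the oral dose reaches the circulation), compound 1 gives 41%, the lowest of the two numbers known here. Compound 2 gives 53% in this assay, and the gap between the two compounds lies beyond the usual scatter of such measurements. Among the measured compounds shown here, no pair of measured compounds differs in only one place, so no single structural step has yet been followed in this assay.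

Compound 3, `CC(C)n1nc(C(=O)O)cc1[C@H]1C[C@](O)(c2ccc(OCc3c(-c4c(Cl)cccc4Cl)noc3C3CC3)cc2Cl)C1`, has not been measured. It differs from compound 1 in one place: 3-carboxy-1-isopropyl-1H-pyrazol-5-yl in place of 4-carboxyphenyl on a saturated ring carbon. Both compounds keep a carboxylic acid on the group at that saturated ring carbon, and the shared core is unchanged. For the measured compounds named here, with no measured step of this kind to lean on, the account expects the step of a number 1 percentage points lower from compound 1 to compound 3 (within the scatter) to stay within the scatter, in no definite direction. Compound 3 is therefore estimated at 40% in this assay, with a range from 20% to 60%.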

Compound 3, oral bioavailability: 18%
Beside the measured number, compound 3's estimate is 22 percentage points above it; measured number below the stated range.
By their numbers in this assay, from the lowest: compound 3; then compound 1; then compound 2.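

In this assay, putting 3-carboxy-1-isopropyl-1H-pyrazol-5-yl in place of 4-carboxyphenyl on the saturated ring carbon gives a number 23 percentage points lower from compound 1 to compound 3 (beyond the scatter). Among these compounds, this is the first single change followed at this position, and it shows that the number responds to the group placed there even though a carboxylic acid remains on that group and the shared core is unchanged. Nothing measured here accounts for the drop.

The step replaces the six-membered aromatic ring with the five-membered one and brings in the isopropyl group in a single change, and the compounds shown do not separate these two parts. As far as these compounds go, it remains open whether a methyl group in place of the isopropyl, or a hydrogen atom there, would give a number nearer to that of compound 1 at this position.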